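Swapping Fluoro for Azido on a Tolerated Nucleoside

A few compounds are considered here, and "the series" means these few. Any claim that something is new, unique, unknown or untested is made for them only; others in the source may bear on it.

Values in an ADME assay on Huh-7 cells (Homo sapiens) for cytotoxicity, read by WST assay, with a stated time of 3 days (a lower number here means that less compound is tolerated, a higher number that more compound is tolerated), follow.

- Compound 1 `Nc1ccnc2c1ncn2[C@@H]1O[C@H](CO)[C@](O)(CO)[C@H]1O` gives 37300 nM
- Compound 2 `Nc1ccnc2c1ncn2[C@@H]1O[C@H](CO)[C@](O)(CF)[C@H]1O` gives > 100000 nM, a limit
- Compound 3 `CNc1ccnc2c1ncn2[C@@H]1O[C@H](CO)[C@](O)(CF)[C@H]1O` gives > 100000 nM, a limit

Compound 2 stands at the limit of > 100000 nM in this assay, at which 2 of the 3 values shown sit, so it offers a limit and no number to start from. Compound 4 `[N-]=[N+]=NC[C@@]1(O)[C@@H](CO)O[C@@H](n2cnc3c(N)ccnc32)[C@@H]1O` has azido in place of fluoro on a saturated chain carbon bound to a saturated ring carbon, counted as azido in place of fluoro on a saturated chain carbon bound to a saturated ring carbon. Among the compounds with values here, only one measured change at this place can be read, and it is an at least 2.6-fold higher number from compound 1 to compound 2 (0.42 log units; beyond the scatter). The other measured change, on a nitrogen on an aromatic ring, is a step that the two limits leave unreadable from compound 2 to compound 3, so it adds nothing here. In this assay, a modest move towards a lower number is therefore expected, or none that can be read, since the step to compound 2 is an at least 2.6-fold higher number from compound 1 to compound 2 (0.42 log units; beyond the scatter) and the group entering is a new one. The expected change is an at least 1.2-fold lower number from compound 2 to compound 4 (0.09 log units; that floor lies within the scatter). Compound 4 is estimated at 80000 nM, with an expected range of 25000 nM to 200000 nM.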

Compound 4, half-maximal cytotoxic concentration: > 100000 nM
Compound 4 gave a limit, no number; the forecaster's own chance of this, stated with the estimate: 50%; middle value at least 1.2-fold (0.09 log units) away from the limit.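

In this assay, exchanging hydroxy for azido on the saturated chain carbon gives an at least 2.6-fold higher number from compound 1 to compound 4 (0.42 log units; beyond the scatter). The rise from compound 1 is therefore no longer tied to fluoro alone: at this place, azido, with 3 heavy atoms against the 1 of fluoro, also leaves the compound at the assay's limit. The steps from compound 2 to compound 3 and from compound 2 to compound 4 cannot be read, and compound 4 now shares the top of the range: the limit of > 100000 nM in this assay, at which 3 of the 4 values shown sit.

Any difference among fluoro, azido and the methyl on the aromatic nitrogen remains hidden behind these limits. On these data alone, it also remains open whether an amine or a carboxylic acid at this place would bring the number back towards that of compound 1.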